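A few compounds are considered here, and "the series" means these few. Any claim that something is new, unique, unknown or untested is made for them only; others in the source may bear on it.

Two compounds of this series carry numbers in a functional assay on DU-145 cells (Homo sapiens) for inhibition, read by trypan blue exclusion, with a stated time of 96 h; on this read-out higher numbers stand for weaker inhibition of growth and lower numbers for stronger inhibition of growth. Compound 1 `Cc1ccc(CS/C(=C/c2ccc(O)cc2)C(=O)c2ccc(Cl)cc2)cc1` gives 10000 nM in this assay, the lowest of the two numbers. Compound 2 `COc1ccc(/C=C(/C(=O)c2ccc(OC)cc2)S(=O)(=O)Cc2ccc([N+](=O)[O-])cc2)cc1` gives 25000 nM in this assay, and the gap from compound 1 up to compound 2 lies beyond the scatter, so compound 1 stands as the stronger of the pair on what has been measured. Compound 3 `Cc1ccc(CS/C(=C/c2c[nH]c3ccc(Cl)cc23)C(=O)c2ccc(Cl)cc2)cc1` has not yet been measured. Its structure differs from that of compound 1 in a single place: 5-chloro-1H-indol-3-yl in place of 4-hydroxyphenyl on a double-bonded chain carbon bound to a double-bonded chain carbon. Within the data shown here, no measured pair shows this same change, so nothing in the data fixes the size or direction of the step; compound 2 differs from compound 1 in several places at once and offers no guide here. The step from compound 1 to compound 3 is expected to be a 2.0-fold lower number from compound 1 to compound 3 (0.30 log units; within the scatter), a modest move toward stronger inhibition of growth, with a real chance that it falls within the scatter. For compound 3 the expected value in this assay is 5000 nM, with a range from 1500 nM to 20000 nM.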

Compound 3, concentration for 50% growth inhibition: 1000 nM
Estimate against measurement, compound 3: 5.0-fold (0.70 log units) above; measured number below the stated range.
By their numbers in this assay, from the lowest: compound 3; then compound 1; then compound 2.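

In this assay, among these compounds, the first single-place comparison shows that 5-chloro-1H-indol-3-yl in place of 4-hydroxyphenyl gives a 10-fold lower number from compound 1 to compound 3 (1.00 log units; beyond the scatter), a step toward stronger inhibition of growth. The position on a double-bonded chain carbon bound to a double-bonded chain carbon therefore accepts a larger group with two aromatic rings, and the 4-hydroxyphenyl group of compound 1 is not required for activity in this series. No measurement at hand explains the gain in compound 3.

The change alters several features at once, as it replaces a single six-membered ring with two fused rings, adds a chlorine and removes the oxygen, so the compounds shown leave open which of these features accounts for the step. A 1H-indol-3-yl group without the chlorine and a 4-chlorophenyl group at this same position would help separate the contribution of the added ring from that of the chlorine.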